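Thiophene for phenyl on a nucleoside core, antiproliferative read-out

This account rests on a few compounds, and the source may have more. Where it says the series, first, only, none or still open, it means among the compounds named here.

The measured compounds:
compound 1 `COc1nc(N)nc2c1c(-c1ccccc1)cn2[C@@H]1O[C@H](CO)[C@@H](O)[C@H]1O` — in a functional assay on HL-60 cells (Homo sapiens) for antiproliferative activity, read by XTT assay, with a stated time of 72 h (on this read-out higher numbers stand for weaker inhibition and lower numbers for stronger inhibition), compound 1 gives > 20000 nM, a limit of the assay.
compound 2 `COc1nc(N)nc2c1c(-c1cccs1)cn2[C@@H]1O[C@H](CO)[C@@H](O)[C@H]1O` — in this assay compound 2 gives > 20000 nM, again a limit.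
compound 3 `CNc1ncnc2c1c(-c1ccccc1)cn2[C@@H]1O[C@H](CO)[C@@H](O)[C@H]1O` — in this assay compound 3 gives > 20000 nM, also a limit.

From compound 1 to compound 2 the change is thiophen-2-yl in place of phenyl on an aromatic carbon. Its step is a step that the two limits leave unreadable from compound 1 to compound 2, since (the limit of > 20000 nM in this assay, at which 3 of the 3 values shown sit). How the core of compound 1 and the core of compound 3 differ is not broken down here.

Compound 4 `CNc1ncnc2c1c(-c1cccs1)cn2[C@@H]1O[C@H](CO)[C@@H](O)[C@H]1O` is not yet measured. From compound 3 to compound 4 the change is thiophen-2-yl in place of phenyl on an aromatic carbon, the same kind of change as before; the two descriptions differ only in that the ring atom two bonds away bears a group of 9 heavy atoms, named in the earlier case as a 3,4-dihydroxy-5-(hydroxymethyl)oxolan-2-yl group.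

For compound 4 in this assay the expected step is a step that the limit leaves unreadable from compound 3 to compound 4, resting on the unreadable step from compound 1 to compound 2 and on (the limit of > 20000 nM in this assay, at which 3 of the 3 values shown sit). Compound 4 is therefore estimated at 30000 nM, most likely reported as a limit once more.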

Compound 4, half-maximal inhibitory concentration: > 20000 nM
Compound 4: only a limit was reported; the forecaster's own chance of this, stated with the estimate: 85%; the middle value lies beyond the limit too.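

In this assay compound 4 gives > 20000 nM, a limit of the assay. No step can be read from compound 3 to compound 4, because neither compound has a value that is more than a limit: the limit of > 20000 nM in this assay, at which 4 of the 4 values shown sit.

The compounds shown leave open how strongly any of the four inhibits, and whether thiophen-2-yl in place of phenyl makes any difference on either core.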